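Methoxy to Fluoro on the Aryl Group of Compound 3

The source may hold more compounds than are shown below. What is called first, only, known or untested is meant among the compounds shown, and "the series" means these compounds.

Compound 1 `Cc1cccc(-c2ccnc(C(=O)Nc3ccc(Oc4ccnc5[nH]ccc45)c(F)c3)c2)c1` in a functional assay on PC-3 cells (Homo sapiens) for cytotoxicity, read by MTT assay, with a stated time of 72 h (on this read-out higher numbers stand for weaker inhibition and lower numbers for stronger inhibition), gives 860 nM.
Compound 2 `Cc1ccc(-c2ccnc(C(=O)Nc3ccc(Oc4ccnc5[nH]ccc45)c(F)c3)c2)c(C)c1` gives 4010 nM.
Compound 3 `COc1ccc(-c2ccnc(C(=O)Nc3ccc(Oc4ccnc5[nH]ccc45)c(F)c3)c2)cc1` gives 20 nM.

Compound 3 stands lowest of the three numbers. The step of a 43-fold lower number from compound 1 to compound 3 (1.63 log units; beyond the scatter) and the step of a 200-fold lower number from compound 2 to compound 3 (2.30 log units; beyond the scatter) both set it well apart from the other two, and the step of a 4.7-fold higher number from compound 1 to compound 2 (0.67 log units; beyond the scatter) shows that the two methyl-bearing compounds also differ from each other beyond the scatter. Compound 4 `O=C(Nc1ccc(Oc2ccnc3[nH]ccc23)c(F)c1)c1cc(-c2ccc(F)cc2)ccn1` is reached from compound 3 by the change (fluoro in place of methoxy on an aromatic carbon). Among the measured compounds shown here, no measured step tests this exact exchange: the two steps that end at compound 3 replace methyl-bearing phenyl groups with the 4-methoxyphenyl group, and both were large, but they do not show how much of that gain is tied to the methoxy itself rather than to having a single substituent on this ring. On these data alone, whether a fluoro at the same carbon carries the same gain is untested. The expected outcome is a moderate move upward, a 6.0-fold higher number from compound 3 to compound 4 (0.78 log units; beyond the scatter), with wide uncertainty. Compound 4 is therefore estimated at 120 nM in this assay, within a range from 25 nM to 600 nM.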

Compound 4, half-maximal inhibitory concentration: 710 nM
Estimate against measurement, compound 4: 5.9-fold (0.77 log units) below, outside the stated range (above it).
By their numbers in this assay, from the lowest: compound 3; then compounds 4 and 1 (each within the scatter of the next); then compound 2.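

In this assay, exchanging methoxy for fluoro on this aromatic carbon, para to a large group, removes most of what set compound 3 apart (a 36-fold higher number from compound 3 to compound 4 (1.55 log units; beyond the scatter)), so among the compounds shown, a single substituent at this place does not by itself bring the number down to that of compound 3. The 4-fluorophenyl group cannot be told apart from the 3-methylphenyl group (a 1.2-fold lower number from compound 1 to compound 4 (0.08 log units; within the scatter)), yet it still stands clear of the 2,4-dimethylphenyl group (a 5.6-fold lower number from compound 2 to compound 4 (0.75 log units; beyond the scatter)), which leaves the 4-methoxyphenyl group of compound 3 alone at the low end of this short series. No measured evidence is available to explain why methoxy and fluoro part so widely at this carbon.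

The compounds shown leave open whether the gain rests on the oxygen alone or on the whole methoxy group, a question that a hydroxyl or an ethoxy group on the same carbon would help to separate. They also leave open whether another group that enters through a heteroatom, such as a dimethylamino group, would give a number close to that of compound 3 or close to that of compound 4.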